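Trimming One Methoxy Group at the Low Dose

The source may report more compounds than this note shows. Statements on the series, on what has been measured and on what is new or still open speak of the compounds shown alone.

Three compounds share one core and differ only in the ring on the carbonyl carbon. In a functional assay on ACHN cells (Homo sapiens) for cytotoxicity, read by sulforhodamine B assay, with a stated time of 48 h, tested at 0.01 uM (a higher number here means a weaker effect of the compound at the concentration tested, a lower number a stronger effect), compound 1 `COc1cc(-c2cc(/C=C/C(=O)c3ccc(N)cc3)[nH]n2)cc(OC)c1OC` gives 95%, compound 2 `COc1cc(-c2cc(/C=C/C(=O)c3ccc(Cl)c(Cl)c3)[nH]n2)cc(OC)c1OC` gives 107%, and compound 3 `COc1ccc(C(=O)/C=C/c2cc(-c3cc(OC)c(OC)c(OC)c3)n[nH]2)cc1OC` gives 101%. Compound 3 stands second highest of the three, within the scatter of both others: a number 6 percentage points higher from compound 1 to compound 3 (within the scatter) and a number 6 percentage points lower from compound 2 to compound 3 (within the scatter). Only a number 12 percentage points higher from compound 1 to compound 2 (beyond the scatter) reaches beyond it. Compound 4 `COc1ccc(C(=O)/C=C/c2cc(-c3cc(OC)c(OC)c(OC)c3)n[nH]2)cc1` differs from compound 3 in one place: hydrogen in place of methoxy on an aromatic carbon. For the measured compounds named here, no measured step removes a methoxy group, so the nearest guides are the swaps around compound 3, all small. For compound 4 the expected change is a number 1 percentage points lower from compound 3 to compound 4 (within the scatter), not beyond the scatter. Compound 4 is estimated at 100%, between 88% and 112%.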

Compound 4, a percentage reported as activity, at one concentration (the size of the read-out at that concentration, not a potency): 102%
Compound 4: the middle estimate sits 2 percentage points below what was measured; the measured number falls inside the stated range.
By their numbers in this assay, from the lowest: compounds 1, 3, 4 and 2 (each within the scatter of the next, the first and the last beyond it).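

Taking away one methoxy group, 3,4-dimethoxyphenyl to 4-methoxyphenyl, is a deletion rather than a swap, and in this assay it stays within the scatter (a number 1 percentage points higher from compound 3 to compound 4 (within the scatter)). The new compound also stays within the scatter of the other two (a number 5 percentage points lower from compound 2 to compound 4 (within the scatter); a number 7 percentage points higher from compound 1 to compound 4 (within the scatter)), so this position shows no measurable effect of the methoxy group at this low dose. Nothing available explains this result. On these data alone, whether a hydroxyl group or an ethoxy group on this aromatic carbon would behave the same remains open, as does any difference at higher concentrations.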